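From 4-fluorophenyl to 6-fluoropyridin-3-yl in a cell assay

The source may hold more compounds than are shown below. What is called first, only, known or untested is meant among the compounds shown, and "the series" means these compounds.

Among the compounds with values here, in a functional assay on SW480 cells (Homo sapiens) for antiproliferative activity, read by sulforhodamine B assay, with a stated time of 48 h (a lower number here means a stronger inhibitor, a higher number a weaker inhibitor), compound 2 `COc1ccc(C(=O)/C=C/c2ccccc2-c2ccc(F)cc2)cc1O` gives 340 nM, the lower of the two numbers measured so far. Compound 1 `COc1ccc(C(=O)/C=C/c2ccccc2-c2ccc(F)nc2)cc1OC` gives 15000 nM, a gap well beyond the usual scatter of repeated measurements, so compound 2 is the stronger inhibitor of this pair. Compound 3 `COc1ccc(C(=O)/C=C/c2ccccc2-c2ccc(F)nc2)cc1O` has not yet been measured. It arises from compound 2 with 6-fluoropyridin-3-yl in place of 4-fluorophenyl on an aromatic carbon. That carbon belongs to a six-membered aromatic ring of carbon only and sits ortho to a large group. Within the data shown here, no measured pair isolates this change. Going by these compounds, compound 1 carries the same 6-fluoropyridin-3-yl group but also differs from compound 2 elsewhere, so the size of this group's contribution remains unknown. A moderate move toward a weaker result is expected in this assay, with an estimated step of a 2.4-fold higher number from compound 2 to compound 3 (0.37 log units; beyond the scatter). That expectation leans on compound 1, which shares the new group and gives 15000 nM. For compound 3 the expected value is 800 nM, with an estimated range of 200 nM to 4000 nM.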

Compound 3, half-maximal inhibitory concentration: 1600 nM
Estimate against measurement, compound 3: 2.0-fold (0.30 log units) below; the range from low to high includes it.
By their numbers in this assay, from the lowest: compound 2; then compound 3; then compound 1.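

In this assay, within the data shown here, the exchange of 4-fluorophenyl for 6-fluoropyridin-3-yl on this aromatic carbon now has a size of its own, a 4.7-fold higher number from compound 2 to compound 3 (0.67 log units; beyond the scatter), and this modest loss is the first reading of that change with everything else held constant. Among these compounds, compound 3 also pairs with compound 1, where the only change is hydrogen in place of methyl on an oxygen on the aromatic ring, giving a 9.4-fold lower number from compound 1 to compound 3 (0.97 log units; beyond the scatter), so the wide gap between compound 1 and compound 2 comes from changes in both places, not from the new ring alone. The data shown offer no measured explanation for either step.

Still open is whether the ring exchange would cost a similar amount in a compound carrying the methyl on that oxygen, since the 4-fluorophenyl partner of compound 1 is not among the compounds shown. Also open, going by these compounds, is how other groups would behave, such as a plain phenyl or a pyridin-3-yl without fluorine on the same aromatic carbon, or a longer chain such as ethyl on the oxygen.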